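Full agonist activity retained with pyridin-2-yl in place of thiophen-2-yl

The compounds below may be only part of what the source reports. "The series", "measured", "known", "first", "only" and "open" are said of these compounds alone.

Two compounds sharing the same core, a guanidine carrying an imidazole-bearing chain and an amide, have been tested in a functional assay on cardiac atrium for agonist activity at histamine H2 receptor (Cavia porcellus); on this read-out higher numbers stand for larger maximal responses and lower numbers for smaller maximal responses. Compound 1, `N=C(NCCCc1c[nH]cn1)NC(=O)CC(c1ccccc1)c1ccccn1`, gives 97% in this assay. Compound 2, `CC(CC(=O)NC(=N)NCCCc1c[nH]cn1)c1cccs1`, gives 99% in this assay. On the numbers shown, compound 2 stands level with compound 1: the two values differ by an amount within the usual scatter, so neither can be called larger in any real sense, and both reach essentially the full response of the reference.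

Compound 3, `CC(CC(=O)NC(=N)NCCCc1c[nH]cn1)c1ccccn1`, differs from compound 2 by a single change, (pyridin-2-yl in place of thiophen-2-yl on a saturated chain carbon bound to two saturated chain carbons). Among the compounds with values here, no step between measured compounds isolates this exchange, but both measured compounds already lie near the ceiling of the response, which leaves little room for movement upward and gives no sign of a loss. The step in this assay from compound 2 to compound 3 is therefore expected to be small, a number 2 percentage points lower from compound 2 to compound 3 (within the scatter), not beyond the scatter. Compound 3 is expected to give about 97% in this assay, within a range from 87% to 105%.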

Compound 3, largest response reached (Emax), in percent of the reference or control that the assay uses: 98%
Estimate against measurement, compound 3: 1 percentage points below; the range from low to high includes it.
By their numbers in this assay, from the lowest: compounds 1, 3 and 2 (each within the scatter of the next).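

Exchanging thiophen-2-yl for pyridin-2-yl on a saturated chain carbon bound to two saturated chain carbons can now be read directly in this assay: the step is a number 1 percentage points lower from compound 2 to compound 3 (within the scatter), so a five-membered and a six-membered aromatic ring, each with one hetero atom, stand level at this position. A second comparison concerns methyl in place of phenyl on a saturated chain carbon bound to an aromatic carbon and a saturated chain carbon, and its step in this assay is a number 1 percentage points higher from compound 1 to compound 3 (within the scatter), so these three compounds give no sign that either exchange separates them on this read-out. Nothing available here explains why the compounds stand level.

Going by these compounds, with all three compounds so close together, it remains open which groups at this carbon, if any, would give a clearly smaller maximal response. An amine or a carboxylic acid in place of the aromatic ring, or a longer chain in place of methyl, would test how far this level of response holds.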